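Sulfide to sulfoxide swap on two anilide cores

This account rests on a few compounds, and the source may have more. Where it says the series, first, only, none or still open, it means among the compounds named here.

Measured so far in a functional assay on VCaP cells (Homo sapiens) for antiproliferative activity, read by fluorescence and propidium iodide staining, with a stated time of 96 h; on this read-out lower numbers stand for stronger inhibition and higher numbers for weaker inhibition:
compound 1 `O=C(Nc1ccc(S(F)(F)(F)(F)F)cc1)c1ccc(Sc2ccc(O)cc2)cc1` gives 7150 nM
compound 2 `O=C(Nc1ccccc1C(F)(F)F)c1ccc(Sc2ccc(O)cc2)cc1` gives 32300 nM
compound 3 `O=C(Nc1ccc(S(F)(F)(F)(F)F)cc1)c1ccc([S+]([O-])c2ccc(O)cc2)cc1` gives 3530 nM

Compound 3 differs from compound 1 in one place: a group of 9 heavy atoms (6 carbon, 2 oxygen, 1 sulfur; one six-membered aromatic ring of carbon only) in place of a group of 8 heavy atoms (6 carbon, 1 oxygen, 1 sulfur; one six-membered aromatic ring of carbon only), on an aromatic carbon. This change made a modest step, a 2.0-fold lower number from compound 1 to compound 3 (0.31 log units; beyond the scatter).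

Compound 2 is the weakest of the three measured compounds; its steps to compound 1 and to compound 3 both lie beyond the scatter. How the core of compound 2 differs from the core of compound 1 is not broken down here.

Compound 4 `O=C(Nc1ccccc1C(F)(F)F)c1ccc([S+]([O-])c2ccc(O)cc2)cc1` is not yet measured. It stands to compound 2 as compound 3 stands to compound 1: a group of 9 heavy atoms (6 carbon, 2 oxygen, 1 sulfur; one six-membered aromatic ring of carbon only) in place of a group of 8 heavy atoms (6 carbon, 1 oxygen, 1 sulfur; one six-membered aromatic ring of carbon only), on an aromatic carbon. The place description is the same word for word in both pairs, so this is the same change, occurring twice among the compounds shown, once measured and once open.

Among the compounds with values here, the only measured instance of this change is the step from compound 1 to compound 3, and the expectation for compound 4 rests on that single step alone. Within the data shown here, with no second example on another core, the estimate simply carries the observed step over. Compound 4 is therefore expected to give 16000 nM in this assay, with a plausible range from 7000 nM to 36000 nM. This corresponds to an expected step of a 2.0-fold lower number from compound 2 to compound 4 (0.31 log units; beyond the scatter), matching in direction and roughly in size the measured step from compound 1 to compound 3, because that step was a 2.0-fold lower number from compound 1 to compound 3 (0.31 log units; beyond the scatter). Given that compound 2 starts from 32300 nM, compound 4 is expected to remain a weak inhibitor on this read-out even if the step is realised.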

Compound 4, half-maximal inhibitory concentration: 97600 nM
Estimate against measurement, compound 4: 6.1-fold (0.79 log units) below; measured number above the stated range.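

In this assay, the swap of the (4-hydroxyphenyl)sulfanyl group for its sulfoxide on the other anilide core gave a 3.0-fold higher number from compound 2 to compound 4 (0.48 log units; beyond the scatter), so the weaker of the two sulfides lost further ground on oxidation rather than gaining. Direction and size of this change therefore depend on the core in this series, and a step measured on one core cannot simply be carried to the other: the same change on two cores in this assay, a 2.0-fold lower number (0.31 log units; beyond the scatter) from compound 1 to compound 3 and a 3.0-fold higher number (0.48 log units; beyond the scatter) from compound 2 to compound 4, 6.1-fold (0.79 log units) apart, beyond the scatter of two such steps

Within the data shown here, what this does not show is which feature of the anilide part decides the sign of the step, since the two cores differ there and only one pair exists on each, so two steps give a contrast and not a trend.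

Still open, on these data alone, is how a sulfone at the same sulfur would read on either core, and whether it would extend or reverse each sulfoxide step. Equally open, as far as these compounds go, is which way the sulfoxide step would go on a third anilide carrying a nitrile or a chlorine, which would show whether either measured step is the more typical one.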